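Moving the Trifluoromethyl Group to the Other Ring

The source may hold more compounds than are shown below. What is called first, only, known or untested is meant among the compounds shown, and "the series" means these compounds.

Compound 1 `CC(C)(O)c1cncc(-n2ncc3ccccc32)c1` is tested in an ADME assay on cells for inhibition of cytochrome P450 11B1, mitochondrial (Homo sapiens), read by HTRF, with stated times of 1 h and 3 h (a higher number here means a weaker inhibitor, a lower number a stronger inhibitor), where compound 1 gives 535 nM. Of the two numbers shown, this is the lowest; compound 2 `Cc1nn(-c2cncc(C(C)(C)O)c2)c2ccccc12` gives 779 nM, and the step of a 1.5-fold higher number from compound 1 to compound 2 (0.16 log units; within the scatter) stays within the scatter. Compound 3 `CC(C)(O)c1cncc(-n2nc(C(F)(F)F)c3ccccc32)c1` returns only a limit, > 8300 nM, namely (the limit of > 8300 nM in this assay, at which 1 of the 3 values shown sits). The steps of an at least 15-fold higher number from compound 1 to compound 3 (1.19 log units; beyond the scatter) and an at least 10-fold higher number from compound 2 to compound 3 (1.02 log units; beyond the scatter) were both large. Compound 4 `CC(C)(O)c1cncc(-n2ncc3ccc(C(F)(F)F)cc32)c1` differs from compound 1 by trifluoromethyl in place of hydrogen on an aromatic carbon. The same group entering on a different aromatic carbon weakened inhibition strongly, so a weaker inhibitor is expected here too, though the new place leaves room for a smaller effect. The expected step is a 4.7-fold higher number from compound 1 to compound 4 (0.67 log units; beyond the scatter), and compound 4 is estimated at 2500 nM, between 800 nM and 8000 nM.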

Compound 4, half-maximal inhibitory concentration: > 8300 nM
Compound 4: only a limit was reported; the forecaster's own chance of this, stated with the estimate: 20%; middle value at least 3.3-fold (0.52 log units) away from the limit.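

Trifluoromethyl in place of hydrogen on this aromatic carbon gives an at least 15-fold higher number from compound 1 to compound 4 (1.19 log units; beyond the scatter) in this assay, so the large loss seen with compound 3 is not confined to one place on the core. Compound 4 returns only a limit, the same one as compound 3, so these two places cannot be ranked against each other: the limit of > 8300 nM in this assay, at which 2 of the 4 values shown sit.

Going by these compounds, whether a single fluorine atom, a methoxy group or an amine on this carbon would keep inhibition close to that of compound 1 stays open. So does how weak compound 3 and compound 4 really are.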